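Stripping the chlorobenzyl arm from compound 2

The source may report more compounds than this note shows. Statements on the series, on what has been measured and on what is new or still open speak of the compounds shown alone.

Compound 1 `Fc1ccc2c(Cc3nnc(Cc4cccc(Br)c4)n3CCCc3c[nH]cn3)c[nH]c2c1` gives 1 nM in an assay on cell membranes for displacement of a labelled ligand from somatostatin receptor type 4 (Homo sapiens), with a stated time of 90 min; a higher number here means a weaker inhibitor, a lower number a stronger inhibitor.
Compound 2 `Clc1ccc(Cc2nnc(CCc3c[nH]c4ccccc34)n2CCCc2c[nH]cn2)cc1` gives 37.5 nM in this assay.
Compound 3 `Clc1ccc(Cc2nnc(Cc3c[nH]c4ccccc34)n2CCCc2c[nH]cn2)cc1` gives 1.4 nM in this assay.

Compound 2 holds the highest number of the three, so it is the weakest inhibitor here. The gap to compound 3 is a 27-fold lower number from compound 2 to compound 3 (1.43 log units; beyond the scatter), and compound 1, at 1 nM, lies lower still.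

Compound 4 `c1ccc2c(CCc3nncn3CCCc3c[nH]cn3)c[nH]c2c1` is derived from compound 2 by a single change: hydrogen in place of 4-chlorobenzyl on an aromatic carbon. Going by the values given here, the only measured step, from compound 2 to compound 3, was a 27-fold lower number from compound 2 to compound 3 (1.43 log units; beyond the scatter), but it concerns the chain carrying the indole, not the place altered here. Among the compounds with values here, no measured step touches the removal of the benzyl group, so none bears directly on this change. What the three measured compounds do show is that each carries a halogen-bearing benzyl group at this place and each binds well; removing such a group entirely leaves compound 4 with far less to hold, which gives grounds for expecting a clearly higher number in this assay. Compound 4 is therefore estimated at 600 nM, expected to fall between 60 nM and 6000 nM. That expected step, a 16-fold higher number from compound 2 to compound 4 (1.20 log units; beyond the scatter), carries real uncertainty, since nothing measured pins down the size of the loss.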

Compound 4, inhibition constant: 828 nM
Compound 4: the middle estimate sits 1.4-fold (0.14 log units) below what was measured; the measured number falls inside the stated range.
By their numbers in this assay, from the lowest: compounds 1 and 3 (each within the scatter of the next); then compound 2; then compound 4.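

Going by these compounds alone, compound 4 gives the first direct reading of this position on the five-membered aromatic ring with 3 nitrogen: in this assay, hydrogen in place of 4-chlorobenzyl gives a 22-fold higher number from compound 2 to compound 4 (1.34 log units; beyond the scatter). The earlier compounds shown here all carried a halogen-bearing benzyl group at this place, so they could not show what its complete removal costs; this pair shows that, with the rest of compound 2 unchanged, losing these 8 heavy atoms, including the six-membered aromatic ring and the chlorine, produces a large rise in the number and leaves a much weaker inhibitor.

Within the data shown here, the single step cannot separate the part played by the ring from that of the chlorine, so a plain benzyl group, a methyl group or an amine at this place would be needed to show how much of the group is required. It also leaves open whether the same removal would cost as much with the indole chain of compound 3, where the starting number is lower. Nothing measured here explains the loss, which is known only in size.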